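The compounds below may be only part of what the source reports. "The series", "measured", "known", "first", "only" and "open" are said of these compounds alone.

In an ADME assay on Huh-7 cells (Homo sapiens) for cytotoxicity, read by a luciferase reporter and WST assay, with a stated time of 3 days (on this read-out lower numbers stand for higher toxicity in this test and higher numbers for lower toxicity in this test), compound 1 `O=C(Nc1ccccc1)c1c(NO)cc(-c2ccccc2)oc1=O` gives 11600 nM as a measured number. Compound 2 `CNC(=O)c1c(NO)cc(-c2ccccc2)oc1=O` reads > 20000 nM and this is a limit, not a number. Compound 3 `CNC(=O)c1c(NO)cc(-c2ccc(C)cc2)oc1=O` reads > 20000 nM and this too is a limit. Compound 2 thus has no exact place (the limit of > 20000 nM in this assay, at which 2 of the 3 values shown sit). Compound 4 `O=C(NCc1ccccc1)c1c(NO)cc(-c2ccccc2)oc1=O` differs from it by phenyl in place of hydrogen on a saturated chain carbon bound to an amide-type nitrogen, which turns methyl into benzyl. The measured guides are a step that the two limits leave unreadable from compound 2 to compound 3 and, nearer to this change, an at least 1.7-fold higher number from compound 1 to compound 2 (0.23 log units; that floor lies within the scatter) in which methyl replaces phenyl. Going by the values given here, compound 1 shows 11600 nM with a phenyl on the amide-type nitrogen, and that is the only number here to lean on. The expected result is a small move toward a lower number (an at least 1.2-fold lower number from compound 2 to compound 4 (0.09 log units; that floor lies within the scatter)). Compound 4 is estimated at 16000 nM with a range from 8000 nM to 28000 nM and it may yet return only a limit.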

Compound 4, half-maximal cytotoxic concentration: > 20000 nM
Compound 4: only a limit was reported; the forecaster's own chance of this, stated with the estimate: 45%; at least 1.2-fold (0.09 log units) between middle value and limit.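

In this assay compound 4 gives a limit and not a number, so benzyl on the amide-type nitrogen sits at the same limit as methyl, and the steps between limits cannot be read: the limit of > 20000 nM in this assay, at which 3 of the 4 values shown sit.
Going by these compounds alone, the one readable step is an at least 1.7-fold higher number from compound 1 to compound 4 (0.23 log units; that floor lies within the scatter) and it sets benzyl against phenyl on that nitrogen. Placing a phenyl on the saturated chain carbon therefore still yields no exact number, which leaves compound 1 alone with one.

Going by these compounds, whether an amine, a carboxylic acid or a longer chain on this nitrogen would give a measured number stays open.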